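Isopropylamino in Place of Pyrrolidinyl: Expected Growth Inhibition

This account rests on a few compounds, and the source may have more. Where it says the series, first, only, none or still open, it means among the compounds named here.

Compound 2 `COc1cc2ccc(=O)oc2cc1OCC(O)CN1CCCC1` gives 0.5% in a functional assay on HUVEC cells (Homo sapiens) for inhibition, read by MTT assay, with a stated time of 24 h, tested at 10 uM (on this read-out higher numbers stand for more inhibition of growth at the one concentration tested and lower numbers for less inhibition of growth), the smallest of the three numbers shown, yet compound 3 `COc1cc2ccc(=O)oc2cc1OCC(=O)c1ccccc1` with 3.4% and compound 1 `COc1ccc(C(=O)COc2cc3oc(=O)ccc3cc2OC)cc1` with 7.6% both sit within the scatter of it. Among the measured compounds shown here, the one measured step, a number 4.2 percentage points lower from compound 1 to compound 3 (within the scatter), stayed within the scatter. Compound 4 `COc1cc2ccc(=O)oc2cc1OCC(O)CNC(C)C` differs from compound 2 by isopropylamino in place of pyrrolidin-1-yl on a saturated chain carbon, two bonds along the chain from an oxygen on a saturated carbon. For the measured compounds named here, no measured step touches this part of the structure, and every number here lies within the scatter of every other, so no step beyond the scatter is expected from this change. Compound 4 is therefore estimated at 2%, in a range from -8% to 12%, meaning an expected step of a number 1.5 percentage points higher from compound 2 to compound 4 (within the scatter).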

Compound 4, percent growth inhibition at one concentration: 0.1%
Compound 4: the middle estimate sits 1.9 percentage points above what was measured; low and high end bracket the measured number.
By their numbers in this assay, from the lowest: compounds 4, 2, 3 and 1 (each within the scatter of the next).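

In this assay, among the compounds shown here, isopropylamino in place of pyrrolidin-1-yl on this saturated chain carbon gives a number 0.4 percentage points lower from compound 2 to compound 4 (within the scatter), the first measured step at this part of the structure. Losing the ring and gaining a hydrogen-bond donor thus leaves the number within the scatter. Nothing measured on these compounds explains this result.

From the compounds shown here alone, whether a piperidine, a morpholine or a carboxylic acid at this place would give a step beyond the scatter remains open. So does whether a longer chain carrying the amine would do so.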